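Amino in Place of Hydroxy on the Sulfur-Linked Chain

The source may report more compounds than this note shows. Statements on the series, on what has been measured and on what is new or still open speak of the compounds shown alone.

Compound 3 `CC(C)c1n[nH]c2c(NCc3ccc(-c4ccccn4)cc3)nc(SCCCO)nc12` has the lowest of the three numbers in a functional assay on HT cells (Homo sapiens) for antiproliferative activity, read by fluorescence, with a stated time of 72 h (on this read-out lower numbers stand for stronger inhibition of growth and higher numbers for weaker inhibition of growth), giving 109 nM. Compound 2 `CCC(O)CSc1nc(NCc2ccc(-c3ccccn3)cc2)c2[nH]nc(C(C)C)c2n1` gives 273 nM, with a step of a 2.5-fold lower number from compound 2 to compound 3 (0.40 log units; beyond the scatter). Compound 1 `CC(C)c1n[nH]c2c(NCc3ccc(-c4ccccn4)cc3)nc(SCCNC(=N)N)nc12` gives 390 nM, with a step of a 3.6-fold lower number from compound 1 to compound 3 (0.55 log units; beyond the scatter), while a 1.4-fold lower number from compound 1 to compound 2 (0.15 log units; within the scatter). Compound 4 `CC(C)c1n[nH]c2c(NCc3ccc(-c4ccccn4)cc3)nc(SCCCN)nc12` differs from compound 3 by amino in place of hydroxy on a saturated chain carbon, three bonds along the chain from a sulfur. Going by the values given here, no measured step swaps hydroxy for amino directly; the nearest guide is compound 1, whose chain ends in nitrogen and whose number stands higher, the step of a 3.6-fold lower number from compound 1 to compound 3 (0.55 log units; beyond the scatter) lying beyond the scatter. Compound 4 is therefore expected to show a 1.8-fold higher number from compound 3 to compound 4 (0.26 log units; within the scatter), a modest move toward weaker inhibition. The estimate for compound 4 in this assay is 200 nM, within a range of 80 nM to 500 nM.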

Compound 4, concentration for 50% growth inhibition: 120 nM
Beside the measured number, compound 4's estimate is 1.7-fold (0.22 log units) above it; the range from low to high includes it.
By their numbers in this assay, from the lowest: compounds 3 and 4 (each within the scatter of the next); then compounds 2 and 1 (each within the scatter of the next).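

In this assay the direct exchange of hydroxy for amino gives a 1.1-fold higher number from compound 3 to compound 4 (0.04 log units; within the scatter), so 3-aminopropyl and 3-hydroxypropyl cannot be told apart at this place. The amine-ended chain also stands apart from the other two chains, with a 3.3-fold lower number from compound 1 to compound 4 (0.51 log units; beyond the scatter) and a 2.3-fold lower number from compound 2 to compound 4 (0.36 log units; beyond the scatter), so a chain-end nitrogen does not by itself go with the higher number of compound 1. Nothing shown explains these numbers. Going by these compounds, whether a longer chain, a dimethylamine or a carboxylic acid at the chain end would hold this level remains open.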